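A Larger Group on the Hydroxy Side Chain

This account rests on a few compounds, and the source may have more. Where it says the series, first, only, none or still open, it means among the compounds named here.

In an in vitro ADME assay on microsomes (Rattus norvegicus) for metabolic stability (a lower number here means that the compound disappears faster, a higher number that the compound lasts longer), compound 1 `CC(=O)N1CCc2c(C)c3c(n2-c2ccc(C(N)=O)c(c2)N[C@@H](C)[C@H](C)C1)CC(C)(C)CC3=O` gives 0.333 h and compound 2 `Cc1c2c(n3c1CCN(C(=O)[C@H](C)O)C[C@@H](C)[C@H](C)Nc1cc-3ccc1C(N)=O)CC(C)(C)CC2=O` gives 0.483 h, two numbers within the scatter of each other. Compound 3 `Cc1c2c(n3c1CCN(C(=O)[C@@H](O)C(C)C)C[C@@H](C)[C@H](C)Nc1cc-3ccc1C(N)=O)CC(C)(C)CC2=O` differs from compound 2 by isopropyl in place of methyl on a saturated chain carbon bound to a carbonyl carbon and an oxygen on a saturated carbon. For the measured compounds named here, the one measured step, a 1.5-fold higher number from compound 1 to compound 2 (0.16 log units; within the scatter), concerns this same side chain and stayed within the scatter, so no step beyond the scatter is expected in this assay. The expected step is a 1.2-fold lower number from compound 2 to compound 3 (0.06 log units; within the scatter). For compound 3 the estimate is 0.42 h, within an expected range of 0.2 h to 0.85 h.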

Compound 3, half-life: 0.317 h
Compound 3: middle estimate off by 1.3-fold (0.12 log units), on the high side; the measured number falls inside the stated range.
By their numbers in this assay, from the lowest: compounds 3, 1 and 2 (each within the scatter of the next).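

In this assay the larger isopropyl in place of methyl on this saturated chain carbon gives a 1.5-fold lower number from compound 2 to compound 3 (0.18 log units; within the scatter) and 1-hydroxy-2-methylpropyl in place of methyl on a carbonyl carbon gives a 1.1-fold lower number from compound 1 to compound 3 (0.02 log units; within the scatter) so both steps stay within the scatter. Across methyl, 1-hydroxyethyl and 1-hydroxy-2-methylpropyl on this carbonyl carbon, the half-life therefore shows no difference beyond the scatter. No evidence at hand bears on this result. On these data alone, whether an amine, a carboxylic acid or a longer chain in place of isopropyl would also stay within the scatter remains open.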